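A few compounds are considered here, and "the series" means these few. Any claim that something is new, unique, unknown or untested is made for them only; others in the source may bear on it.

Working notes on the series. Within the data shown here, in a functional assay on A549 cells (Homo sapiens) for cytotoxicity, read by WST assay, with a stated time of 48 h (a higher number here means a weaker inhibitor, a lower number a stronger inhibitor), compound 3 `COc1ccc2c(C(=O)/C(C#N)=C/c3c[nH]c4ccccc34)c[nH]c2c1` gives 7500 nM, the higher of the two true numbers so far. Compound 1 `COc1ccc2c(/C=C(\C#N)C(=O)c3c[nH]c4cc(OC)ccc34)c[nH]c2c1` is the nearest, with 1700 nM. Compound 2 `COc1ccc2c(C(=O)/C(C#N)=C/c3cn(Cc4ccc(Cl)cc4)c4ccccc34)c[nH]c2c1` gives > 50000 nM, which is a limit of the assay and not a number.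

The change under consideration leads to compound 4 `COc1ccc(Cn2cc(/C=C(\C#N)C(=O)c3c[nH]c4cc(OC)ccc34)c3ccccc32)cc1`: 4-methoxybenzyl in place of hydrogen on an aromatic nitrogen. In words, 4-methoxybenzyl takes the place of hydrogen on an aromatic nitrogen.

The closest measured precedent is an at least 6.6-fold lower number from compound 2 to compound 3 (0.82 log units; beyond the scatter). That step removes a 4-chlorobenzyl from an aromatic nitrogen, so it runs opposite to the change at hand, and its size is only a bound. The other measured step, a 4.4-fold higher number from compound 1 to compound 3 (0.64 log units; beyond the scatter), is a different change, hydrogen in place of methoxy on an aromatic carbon, and it bears little on this question.

A rise of at least modest size beyond the scatter is therefore expected in this assay on adding the benzyl group. The expected step is a 4.7-fold higher number from compound 3 to compound 4 (0.67 log units; beyond the scatter). The estimate for compound 4 is 35000 nM, with an expected range from 10000 nM to 80000 nM. Compound 4 could also return only a limit, given (the limit of > 50000 nM in this assay, at which 1 of the 3 values shown sits).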

Compound 4, half-maximal inhibitory concentration: 28900 nM
Estimate against measurement, compound 4: 1.2-fold (0.08 log units) above, and the stated range covers the measured number.
By their numbers in this assay, from the lowest: compound 1; then compound 3; then compound 4. At a limit, above all of these: compound 2.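

In this assay, the 4-methoxybenzyl group on the aromatic nitrogen gives a step with a true number at both ends, a 3.9-fold higher number from compound 3 to compound 4 (0.59 log units; beyond the scatter), so a cost for a substituted benzyl at this position now has a size and not only a bound. Methoxy in place of chloro on the benzyl ring gives an at least 1.7-fold lower number from compound 2 to compound 4 (0.23 log units; that floor lies within the scatter), and with that floor inside the scatter the two benzyl groups cannot be put in order, though neither compound 2 nor compound 4 falls below the number of compound 3. Among these compounds, compound 2 remains a limit and not a number, the only such value: the limit of > 50000 nM in this assay, at which 1 of the 4 values shown sits.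

The compounds shown leave open whether the rise in the number follows from the benzyl ring itself or from any group on this nitrogen, a question that a methyl or a short chain ending in an amine at the same place would address. Also open, as far as these compounds go, is whether the methoxy on the core of compound 1, with its 1700 nM, would keep its lower number once a benzyl group sits on the aromatic nitrogen.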